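Microsomal clearance notes: from compound 3 to compound 4

A few compounds are considered here, and "the series" means these few. Any claim that something is new, unique, unknown or untested is made for them only; others in the source may bear on it.

Measured compounds:
compound 1 `CC(C)(O)C#Cc1cc(C(O)(C(F)(F)F)C(F)(F)F)cnc1N1CCN(S(=O)(=O)c2ccc(N)nc2)CC1` gives < 14 mL.min-1.g-1 in an ADME assay (liver) for metabolic stability, with Liver microsome (Homo sapiens) as the target, using microsomes and NADPH, with a stated time of 30 min, tested at 1 uM (a lower number here means slower removal, a higher number faster removal of the compound), a limit of the assay.
compound 2 `Cn1cc(-c2cc(C(O)(C(F)(F)F)C(F)(F)F)cnc2N2CCN(S(=O)(=O)c3ccc(N)nc3)CC2)cn1` gives 19 mL.min-1.g-1.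
compound 3 `CC(C)n1cc(-c2cc(C(O)(C(F)(F)F)C(F)(F)F)cnc2N2CCN(S(=O)(=O)c3ccc(N)nc3)CC2)cn1` gives 38 mL.min-1.g-1.

Compound 3 holds the highest of the two numbers; compound 2 is nearest, a 2.0-fold higher number from compound 2 to compound 3 (0.30 log units; within the scatter). Compound 1 sits at a limit (the limit of < 14 mL.min-1.g-1 in this assay, at which 1 of the 3 values shown sits). The other steps are an at least 1.3-fold higher number from compound 1 to compound 2 (0.13 log units; that floor lies within the scatter) and an at least 2.7-fold higher number from compound 1 to compound 3 (0.43 log units; beyond the scatter).

Compound 4 `Nc1ccc(S(=O)(=O)N2CCN(c3ncc(C(O)(C(F)(F)F)C(F)(F)F)cc3-c3cncc(F)c3)CC2)cn1` differs from compound 3 in one place: 5-fluoropyridin-3-yl in place of 1-isopropyl-1H-pyrazol-4-yl on an aromatic carbon. The steps that touch this position are a 2.0-fold higher number from compound 2 to compound 3 (0.30 log units; within the scatter) and an at least 2.7-fold higher number from compound 1 to compound 3 (0.43 log units; beyond the scatter); none replaces the five-membered ring with a six-membered one, so the change is new to the series. Since the isopropyl that distinguished compound 3 is lost, a somewhat lower number is expected for compound 4, a 1.7-fold lower number from compound 3 to compound 4 (0.24 log units; within the scatter), though it may stay within the scatter. Compound 4 is estimated at 22 mL.min-1.g-1, between 10 mL.min-1.g-1 and 48 mL.min-1.g-1.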

Compound 4, intrinsic clearance in microsomes: 24 mL.min-1.g-1
The estimate for compound 4 lay 1.1-fold (0.04 log units) below the measured number, and the stated range covers the measured number.
By their numbers in this assay, from the lowest: compounds 2, 4 and 3 (each within the scatter of the next). At a limit, below all of these: compound 1.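

Replacing either pyrazole with 5-fluoropyridin-3-yl on this aromatic carbon gives a 1.6-fold lower number from compound 3 to compound 4 (0.20 log units; within the scatter) and a 1.3-fold higher number from compound 2 to compound 4 (0.10 log units; within the scatter), so in this assay a six-membered aromatic ring here cannot be told apart from a five-membered one. Compound 1 is a limit of the assay, so an at least 1.7-fold higher number from compound 1 to compound 4 (0.23 log units; that floor lies within the scatter) is only a floor: the limit of < 14 mL.min-1.g-1 in this assay, at which 1 of the 4 values shown sits.

On these data alone, whether the fluorine contributes to this clearance remains open. So does whether a pyridine without fluorine, or one carrying an amine or a carboxylic acid, would leave this range.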